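The compounds below may be only part of what the source reports. "The series", "measured", "known", "first", "only" and "open" are said of these compounds alone.

Compound 1 `CC(C)n1ncc2c(C(=O)Nc3ccc(F)cc3)cc(-c3cccs3)nc21`: > 200000 nM, a limit of the assay.
Compound 2 `CC(C)n1ncc2c(C(=O)Nc3cccc(C(N)=O)c3)cc(-c3cccs3)nc21`: 25000 nM.
Compound 3 `CC(C)n1ncc2c(C(=O)Nc3ncccn3)cc(-c3cccs3)nc21`: 75000 nM.

In an ADME assay on LLC-MK2 cells (Macaca mulatta) for cytotoxicity, read by spectrophotometry and crystal violet staining, with a stated time of 4 days (a higher number here means that more compound is tolerated, a lower number that less compound is tolerated), compound 3 is the higher of the two actual numbers, with a 3.0-fold higher number from compound 2 to compound 3 (0.48 log units; beyond the scatter). The third value, that of compound 1, is a limit.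

Compound 4 `CC(C)n1ncc2c(C(=O)Nc3ccncc3)cc(-c3cccs3)nc21` differs from compound 3 by pyridin-4-yl in place of pyrimidin-2-yl on an amide-type nitrogen. Three measured steps change the same place: an at least 8.0-fold lower number from compound 1 to compound 2 (0.90 log units; beyond the scatter), an at least 2.6-fold lower number from compound 1 to compound 3 (0.42 log units; beyond the scatter) and a 3.0-fold higher number from compound 2 to compound 3 (0.48 log units; beyond the scatter). All are modest or at least modest, and none is this exact swap. No step beyond the scatter is therefore expected, and the estimated step is a 1.1-fold lower number from compound 3 to compound 4 (0.03 log units; within the scatter). Compound 4 is estimated at 70000 nM, with an expected range of 25000 nM to 200000 nM.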

Compound 4, half-maximal cytotoxic concentration: 6300 nM
For compound 4 the middle estimate is 11-fold (1.05 log units) above the measured one; measured number below the stated range.
By their numbers in this assay, from the lowest: compound 4; then compound 2; then compound 3. At a limit, above all of these: compound 1.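

In this assay, the amide-type nitrogen shows that a swap between two six-membered aromatic rings of equal heavy-atom count can be large: a 12-fold lower number from compound 3 to compound 4 (1.08 log units; beyond the scatter). Pyridin-4-yl also falls under 3-carbamoylphenyl, with a 4.0-fold lower number from compound 2 to compound 4 (0.60 log units; beyond the scatter), which leaves compound 4 with the lowest number shown. Against 4-fluorophenyl, an at least 31-fold lower number from compound 1 to compound 4 (1.50 log units; beyond the scatter) is only a bound, since compound 1 stands at a limit: the limit of > 200000 nM in this assay, at which 1 of the 4 values shown sits.

As far as these compounds go, it remains open whether the drop follows the number of ring nitrogens or their place in the ring. From the compounds shown here alone, how pyridin-3-yl or pyridin-2-yl would read on this nitrogen also remains open.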